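The compounds below may be only part of what the source reports. "The series", "measured", "known", "first", "only" and "open" are said of these compounds alone.

Measured in an ADME assay on J774.A1 cells (Mus musculus) for cytotoxicity; a higher number here means that more compound is tolerated, a lower number that less compound is tolerated:
- Compound 1 `Fc1ccc(N2CCN(c3nc(-n4ccc5ccccc54)c4ccccc4n3)CC2)cc1`: 23.4 ug/mL
- Compound 2 `c1ccc(N2CCN(c3nc(-n4ccc5ccccc54)c4ccccc4n3)CC2)cc1`: 5.67 ug/mL

Compound 2 stands at the lower end of this pair, at 5.67 ug/mL, while compound 1 gives 23.4 ug/mL. Compound 3 `CN1CCN(c2nc(-n3ccc4ccccc43)c3ccccc3n2)CC1` keeps the shared core but carries methyl in place of phenyl on an amine nitrogen in a ring. Within the data shown here, only one measured step bears on this, and only indirectly: a 4.1-fold lower number from compound 1 to compound 2 (0.62 log units; beyond the scatter). Among the measured compounds shown here, that step is a different change, hydrogen in place of fluoro on an aromatic carbon, and no measured step covers the loss of the phenyl. For the measured compounds named here, a modest rise in this assay is therefore expected, no larger than that step, though with little certainty about its direction. The estimated change is a 2.1-fold higher number from compound 2 to compound 3 (0.33 log units; beyond the scatter). Compound 3 is expected at 12 ug/mL, with an estimated range from 4 ug/mL to 36 ug/mL.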

Compound 3, half-maximal cytotoxic concentration: 7.27 ug/mL
Compound 3: the middle estimate sits 1.7-fold (0.22 log units) above what was measured; measured number inside the range.
By their numbers in this assay, from the lowest: compounds 2 and 3 (each within the scatter of the next); then compound 1.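

In this assay, methyl in place of phenyl on the amine nitrogen in the ring gives a 1.3-fold higher number from compound 2 to compound 3 (0.11 log units; within the scatter), so at this position the small group and the aromatic ring cannot be told apart. Set against the 4-fluorophenyl group, the same position gives a 3.2-fold lower number from compound 1 to compound 3 (0.51 log units; beyond the scatter), which leaves compound 1 alone as the most tolerated of the three, while compound 2 and compound 3 sit together. Nothing available accounts for why the fluoro-bearing ring stands apart from both the phenyl and the methyl.

The compounds shown leave open whether the higher number of compound 1 is particular to fluoro or would also appear with chloro or methoxy on that phenyl ring. They also leave open whether a benzyl group or a longer chain on this nitrogen would stay with compound 2 and compound 3.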